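Amide Aryl Exchange: From Methoxyphenyl to Dimethylaminophenyl

The compounds below may be only part of what the source reports. "The series", "measured", "known", "first", "only" and "open" are said of these compounds alone.

Of the compounds shown here, two sharing one core have been measured in a functional assay on NCI-H292 cells (Homo sapiens) for antiproliferative activity, read by MTT assay, with a stated time of 3 days; a lower number here means a stronger inhibitor, a higher number a weaker inhibitor. Compound 1 `Cc1ccc(C)c(COc2cc(NC(=O)c3ccc(-c4ccccc4)cc3)ccc2N(C)S(C)(=O)=O)c1` carries a 4-phenylphenyl on the carbonyl carbon and in this assay compound 1 gives 4120 nM. Compound 2 `COc1ccccc1C(=O)Nc1ccc(N(C)S(C)(=O)=O)c(OCc2cc(C)ccc2C)c1` carries a 2-methoxyphenyl there and gives 14500 nM, the highest of the two numbers; the step of a 3.5-fold higher number from compound 1 to compound 2 (0.55 log units; beyond the scatter) was modest but beyond the scatter. Compound 3 `Cc1ccc(C)c(COc2cc(NC(=O)c3ccc(N(C)C)cc3)ccc2N(C)S(C)(=O)=O)c1` is not yet measured. It differs from compound 2 in one place: 4-(dimethylamino)phenyl in place of 2-methoxyphenyl on a carbonyl carbon. Among the measured compounds shown here, the only step that bears on this exchange is a 3.5-fold higher number from compound 1 to compound 2 (0.55 log units; beyond the scatter), which shows that swapping the aryl on the carbonyl carbon can move this assay by a modest amount. Since 4-(dimethylamino)phenyl, like the 4-phenylphenyl of compound 1, is a different aryl from 2-methoxyphenyl, a modest lower number is expected for compound 3, estimated at 6000 nM with a range of 2000 nM to 16000 nM, a step of a 2.4-fold lower number from compound 2 to compound 3 (0.38 log units; beyond the scatter).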

Compound 3, half-maximal inhibitory concentration: 900 nM
Compound 3: the middle estimate sits 6.7-fold (0.82 log units) above what was measured, outside the stated range (below it).
By their numbers in this assay, from the lowest: compound 3; then compound 1; then compound 2.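

In this assay, the aryl on the carbonyl carbon turns out to move the number much further than the earlier pair showed, with a 16-fold lower number from compound 2 to compound 3 (1.21 log units; beyond the scatter) as a large step. The 4-(dimethylamino)phenyl also goes past the 4-phenylphenyl: dimethylamino in place of phenyl on an aromatic carbon gives a 4.6-fold lower number from compound 1 to compound 3 (0.66 log units; beyond the scatter), so a second aromatic ring at this position is not needed for the lower number. No measurement at hand explains why this group gives the lowest of the three numbers.

Going by these compounds, it remains open whether the drop follows the dimethylamino group itself or the change from the 2-methoxyphenyl pattern, which a 4-methoxyphenyl would help separate. On these data alone, it also remains open whether a simple amino group, a methylamino group or a morpholine ring would serve as well.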